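The compounds below may be only part of what the source reports. "The series", "measured", "known", "first", "only" and "open" are said of these compounds alone.

Compound 1 `ClCc1ccc(Cn2cnc3c(Cl)ncnc32)cc1` is the reference point here. In a functional assay on SN12C cells (Homo sapiens) for cytotoxicity, read by sulforhodamine B assay, with a stated time of 48 h (a lower number here means a stronger inhibitor of growth, a higher number a weaker inhibitor of growth), compound 1 gives 2340 nM, the lowest of the three numbers in hand, though neither of the other two is separated from it by more than the usual scatter. Compound 3 `ClCc1cccc(Cn2cnc3nc(Cl)nc(Cl)c32)c1` gives 2750 nM in this assay, a gap from compound 1 that falls well inside the scatter, and compound 2 `ClCc1cccc(Cn2cnc3c(Cl)nc(Cl)nc32)c1` gives 4670 nM, also within the scatter of compound 1. Going by the values given here, no two of these three compounds differ in a single place, so no step between measured compounds is available to guide what a single change does.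

Compound 4 `ClCc1ccc(Cn2cnc3c(Cl)nc(Cl)nc32)cc1` has not yet been measured in this assay. It differs from compound 1 by chloro in place of hydrogen on an aromatic carbon. Compounds 2 and 3 each carry a second chloro group on the same shared core as compound 4, and both return numbers in this assay that sit within the scatter of compound 1, so the step of a 1.3-fold higher number from compound 1 to compound 4 (0.11 log units; within the scatter) is expected to be small and of no clear direction. Compound 4 is therefore estimated to give about 3000 nM in this assay, most plausibly between 1500 nM and 6500 nM.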

Compound 4, concentration for total growth inhibition: 20900 nM
Beside the measured number, compound 4's estimate is 7.0-fold (0.84 log units) below it; measured number above the stated range.
By their numbers in this assay, from the lowest: compounds 1, 3 and 2 (each within the scatter of the next); then compound 4.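

In this assay, going by these compounds alone, the chloro in place of hydrogen, on the aromatic carbon between two ring nitrogen atoms, gives an 8.9-fold higher number from compound 1 to compound 4 (0.95 log units; beyond the scatter) and is the first step in this set that lies beyond the scatter, showing that this position of the shared core is not indifferent to substitution and that the change here weakens growth inhibition. The earlier compounds shown here could not show this, since none of them differed from another in a single place and their numbers all lay within the scatter. The added chloro does not settle the number alone: compound 2, with the same two chloro groups on the core but its chloromethyl group placed differently on the other ring, gives 4670 nM while compound 4 gives 20900 nM in the same assay.

Nothing in the data shown accounts for the size of this step. Going by these compounds, whether the same weakening would follow with an amine, a methoxy group or a fluoro at this position, rather than chloro, remains open.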